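Trimming a Sulfonamide Substituent: Expected Plasma Free Fraction

This account rests on a few compounds, and the source may have more. Where it says the series, first, only, none or still open, it means among the compounds named here.

In an ADME assay on the whole organism (plasma, Mus musculus, strain CD-1) for protein binding, read by LC-MS, in a xenograft, at a dose of 100 mg/kg by the intraperitoneal route (on this read-out higher numbers stand for a larger free fraction and lower numbers for a smaller free fraction), compound 1 `CC(C)(C)NS(=O)(=O)c1cccc(NC(=O)c2ncc(NS(C)(=O)=O)nc2N2CCC3(CC2)CC3)n1` gives 0.022. Compound 2 `CC(C)(C)NS(=O)(=O)c1cccc(NC(=O)c2ccc(NS(=O)(=O)C3(C)CC3)cc2N2CCC3(CC2)CC3)c1` gives 0.015 in this assay; this number sits close to that of compound 1, a gap within the usual scatter, so the two compounds cannot be told apart on this read-out. Compound 3 `CC(C)(C)NS(=O)(=O)c1cccc(NC(=O)c2ccc(NS(C)(=O)=O)cc2N2CCC3(CC2)CC3)c1` differs from compound 2 in one place: methyl in place of 1-methylcyclopropyl on a sulfonyl sulfur. Among the measured compounds shown here, no measured pair shows such a change, so the expected step is none beyond the scatter, a 1.2-fold higher number from compound 2 to compound 3 (0.08 log units; within the scatter). Compound 3 is therefore estimated at 0.018, with a range from 0.009 to 0.036.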

Compound 3, unbound fraction: 0.007
Beside the measured number, compound 3's estimate is 2.6-fold (0.41 log units) above it; measured number outside the range, below it.
By their numbers in this assay, from the lowest: compound 3; then compounds 2 and 1 (each within the scatter of the next).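

In this assay the swap of 1-methylcyclopropyl for methyl on the sulfonyl sulfur brings a 2.1-fold lower number from compound 2 to compound 3 (0.33 log units; beyond the scatter) and so shows that this position can shift the read-out, if only modestly. In this single pair, the smaller group goes with the smaller free fraction, not the larger one. Nothing measured here explains the step. The compounds shown leave open how an ethyl group, a longer chain or an amine on the sulfonyl sulfur would read, and so whether the free fraction follows the size of this group at all.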